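Removing One Acetyl Group From a Weakly Cytotoxic Ester

The compounds below may be only part of what the source reports. "The series", "measured", "known", "first", "only" and "open" are said of these compounds alone.

Compound 2, `COc1ccc(C(=O)O[C@H]2CC(C)=C[C@@H](OC(C)=O)[C@@]3(C)[C@@H](OC(C)=O)C[C@@](O)(C(C)C)[C@H]23)cc1`, is a doubly acetylated ester. In a functional assay on A549 cells (Homo sapiens) for cytotoxicity, read by MTT assay, with a stated time of 72 h (a higher number here means a weaker inhibitor, a lower number a stronger inhibitor), compound 2 reaches only the limit of the assay, > 100000 nM, so no number is known for it; this is the limit of > 100000 nM in this assay, at which 1 of the 2 values shown sits. Compound 1, `COc1ccc(C(=O)O[C@H]2CC(C)=C[C@H](O)[C@@]3(C)[C@@H](OC(C)=O)C[C@@](O)(C(C)C)[C@H]23)cc1`, is also weak: in this assay compound 1 gives 79600 nM. The unmeasured compound 3, `COc1ccc(C(=O)O[C@H]2CC(C)=C[C@@H](O)[C@@]3(C)[C@@H](OC(C)=O)C[C@@](O)(C(C)C)[C@H]23)cc1`, arises from compound 2 by the change (hydrogen in place of acetyl on an oxygen on a saturated carbon). Going by the values given here, no measured step of this kind is available, so the expectation rests on the two values shown, both of which sit at or near the upper edge of this assay. The expected step, an at least 1.2-fold lower number from compound 2 to compound 3 (0.09 log units; that floor lies within the scatter), is small and, if anything, toward a slightly stronger inhibitor, though it may not exceed the scatter. Compound 3 is therefore estimated at 80000 nM, with a range from 30000 nM to 150000 nM, and a fair chance that only a limit is reported for it again.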

Compound 3, half-maximal inhibitory concentration: > 100000 nM
Compound 3: no number, only a limit; the forecaster's own chance of this, stated with the estimate: 40%; at least 1.2-fold (0.09 log units) between middle value and limit.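

Compound 2 and compound 3 both stand at a limit of this assay, so the change from acetoxy to hydroxy cannot be read at this position, and neither value is a number: the limit of > 100000 nM in this assay, at which 2 of the 3 values shown sit. What the new compound adds is a pair that differs in configuration alone, at a stereocentre on a saturated ring carbon, which gives an at least 1.2-fold higher number from compound 1 to compound 3 (0.09 log units; that floor lies within the scatter). That floor does not establish an order between the two hydroxy compounds, so the role of configuration at this carbon remains unsettled: the fact that compounds 1 and 3 differ only in the configuration as drawn

The compounds shown leave open how the acetoxy to hydroxy change would read in the configuration of compound 1, where a number exists. They also leave open whether an amine or a methoxy group on this carbon would give a readable value in this assay.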